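The compounds below may be only part of what the source reports. "The series", "measured", "known", "first", "only" and "open" are said of these compounds alone.

Measured in a functional assay on HepG2 cells (Homo sapiens) for inhibition, read by MTT assay, with a stated time of 72 h; on this read-out higher numbers stand for weaker inhibition and lower numbers for stronger inhibition:
- compound 1 `Nc1ncnc2c1c(-c1cnc3[nH]ccc3c1)nn2CCCCCCCCC(=O)NO`: 3050 nM
- compound 2 `Nc1nc2cc(-c3nn(CCCCCCCCCC(=O)NO)c4ncnc(N)c34)ccc2o1`: 28600 nM
- compound 3 `Nc1nc2cc(-c3nn(CCC(=O)NO)c4ncnc(N)c34)ccc2o1`: > 150000 nM

The entry for compound 3 is a limit of the assay and not a number. Compound 4 `Nc1nc2cc(-c3nn(CCCCCC(=O)NO)c4ncnc(N)c34)ccc2o1` keeps the core of compound 3 and changes only the chain: 3-(hydroxycarbamoyl)propyl in place of hydroxycarbamoyl on a saturated chain carbon, two bonds along the chain from an aromatic nitrogen. In words, this is 3-(hydroxycarbamoyl)propyl in place of hydroxycarbamoyl on a saturated chain carbon, two bonds along the chain from an aromatic nitrogen.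

For the measured compounds named here, only one measured step bears on this change, a shortening of the chain on the same core: an at least 5.2-fold higher number from compound 2 to compound 3 (0.71 log units; beyond the scatter). The chain of compound 4 is shorter than that of compound 2 and longer than that of compound 3. A partial return towards stronger inhibition is therefore expected in this assay, as an at least 2.5-fold lower number from compound 3 to compound 4 (0.39 log units; beyond the scatter). For compound 4 the estimated value is 60000 nM, with an expected range from 20000 nM to 150000 nM.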

Compound 4, half-maximal inhibitory concentration: 1990 nM
For compound 4 the middle estimate is 30-fold (1.48 log units) above the measured one, and the stated range ends above it.
By their numbers in this assay, from the lowest: compounds 4 and 1 (each within the scatter of the next); then compound 2. At a limit, above all of these: compound 3.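

In this assay, shortening the chain on this core does not simply weaken inhibition, as the earlier step alone suggested: the change gives an at least 75-fold lower number from compound 3 to compound 4 (1.87 log units; beyond the scatter), and the intermediate chain also beats the longest one, with a 14-fold lower number from compound 2 to compound 4 (1.16 log units; beyond the scatter). Of these three compounds, the one with the intermediate chain therefore gives the lowest number, so the effect of chain length does not run in one direction. The first step rests on a limit for compound 3, not on a number: the limit of > 150000 nM in this assay, at which 1 of the 4 values shown sits.

From the compounds shown here alone, whether a chain of some other intermediate length would give a still lower number remains open. So does whether the hydroxycarbamoyl end matters, which a carboxylic acid on the same chain could test.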